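This account rests on a few compounds, and the source may have more. Where it says the series, first, only, none or still open, it means among the compounds named here.

Measured compounds in a functional assay on A549 cells (Homo sapiens) for antiproliferative activity, read by MTT assay, with a stated time of 72 h; on this read-out higher numbers stand for weaker inhibition and lower numbers for stronger inhibition:
- compound 1 `CCNC(=O)c1cc(Oc2ccc(NC(=O)c3cc4cccnc4n(-c4ccccc4)c3=O)cc2)ccn1`: 160 nM
- compound 2 `CCNC(=O)c1cc(Oc2ccc(NC(=O)c3cc4cccnc4n(-c4ccc(F)cc4)c3=O)cc2)ccn1`: 120 nM
- compound 3 `CCNC(=O)c1cc(Oc2ccc(NC(=O)c3cc4cccnc4n(-c4ccc(Br)cc4F)c3=O)cc2)ccn1`: 1820 nM

Compound 3 stands highest of the three numbers in this assay; the nearest is compound 1, the furthest compound 2, and both gaps lie beyond the scatter, so compound 3 is the weakest of the measured set.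

Compound 4 `CCNC(=O)c1cc(Oc2ccc(NC(=O)c3cc4cccnc4n(-c4ccc(F)c(Cl)c4)c3=O)cc2)ccn1` is not yet measured. It differs from compound 3 in one place: 3-chloro-4-fluorophenyl in place of 4-bromo-2-fluorophenyl on an aromatic nitrogen.

Going by the values given here, two measured steps bear on this change. Both an 11-fold higher number from compound 1 to compound 3 (1.06 log units; beyond the scatter) and a 15-fold higher number from compound 2 to compound 3 (1.18 log units; beyond the scatter) show that putting 4-bromo-2-fluorophenyl on the aromatic nitrogen cost a large amount of activity relative to phenyl or 4-fluorophenyl. Compound 4 removes that group, so the larger part of the loss is expected to be recovered. The step of a 1.3-fold lower number from compound 1 to compound 2 (0.12 log units; within the scatter) shows that a fluoro on the phenyl ring by itself changes little. Among the compounds with values here, no measured compound carries a chloro on that ring, so the contribution of the 3-chloro-4-fluorophenyl beyond what a fluoro alone does is unknown, and the estimate is held somewhat away from the level of compound 2.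

Compound 4 is therefore expected to give about 300 nM in this assay, within 100 nM to 1000 nM, a step of a 6.1-fold lower number from compound 3 to compound 4 (0.78 log units; beyond the scatter) that is expected to lie beyond the scatter.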

Compound 4, half-maximal inhibitory concentration: 1920 nM
For compound 4 the middle estimate is 6.4-fold (0.81 log units) below the measured one; the measured number lies above the stated range.
By their numbers in this assay, from the lowest: compounds 2 and 1 (each within the scatter of the next); then compounds 3 and 4 (each within the scatter of the next).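

In this assay the step of a 1.1-fold higher number from compound 3 to compound 4 (0.02 log units; within the scatter) shows that the earlier loss is not peculiar to the 4-bromo-2-fluorophenyl group, since 3-chloro-4-fluorophenyl on the same aromatic nitrogen gives a number within the scatter of it. Adding a chloro to the 4-fluorophenyl ring gives a 16-fold higher number from compound 2 to compound 4 (1.20 log units; beyond the scatter), and 3-chloro-4-fluorophenyl in place of phenyl gives a 12-fold higher number from compound 1 to compound 4 (1.08 log units; beyond the scatter), so a chloro on this ring carries a large cost, whereas the fluoro alone gave only a 1.3-fold lower number from compound 1 to compound 2 (0.12 log units; within the scatter). The four compounds therefore form two groups, phenyl and 4-fluorophenyl in one and the two bromo- or chloro-bearing rings in the other, and none of the four goes against this split, though four compounds are a narrow basis for it.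

Nothing shown gives a reason for the cost of the chloro or bromo substituent. Going by these compounds, it remains open whether a chloro without the fluoro would carry the same cost, and whether a methoxy or an amino group in place of the chloro would keep the number near that of compound 2 at 120 nM.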